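This account rests on a few compounds, and the source may have more. Where it says the series, first, only, none or still open, it means among the compounds named here.

Measured in an in vitro ADME assay on microsomes from liver (Homo sapiens) for metabolic stability; a higher number here means faster removal of the compound, a lower number slower removal:
compound 1 `CCOc1nc2nc(C)cc(Nc3ccc(C(F)(F)F)cc3)n2n1`: 7 mL.min-1.g-1
compound 2 `COCc1nc2nc(C)cc(Nc3ccc(S(F)(F)(F)(F)F)cc3)n2n1`: 5.6 mL.min-1.g-1

These two numbers lie within the usual scatter of repeated measurements, so compound 1 stands level with compound 2 and the two cannot be ranked. Compound 3 `CSc1nc2nc(C)cc(Nc3ccc(C(F)(F)F)cc3)n2n1` keeps the core of compound 1 and carries methylsulfanyl in place of ethoxy on an aromatic carbon. Going by the values given here, no measured pair of compounds shows what a single change of this kind does in this assay, so the data offer no direct guide to its size or direction. No step beyond the scatter is therefore expected, and the best starting point is compound 1 at 7 mL.min-1.g-1. The expected outcome is no change at the digits printed from compound 1 to compound 3 (within the scatter). The estimated value for compound 3 is 7 mL.min-1.g-1, with an expected range from 3.5 mL.min-1.g-1 to 14 mL.min-1.g-1.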

Compound 3, intrinsic clearance in microsomes: 18.7 mL.min-1.g-1
For compound 3 the middle estimate is 2.7-fold (0.43 log units) below the measured one; the measured number lies above the stated range.
By their numbers in this assay, from the lowest: compounds 2 and 1 (each within the scatter of the next); then compound 3.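

In this assay, putting methylsulfanyl in place of ethoxy on this aromatic carbon gives a 2.7-fold higher number from compound 1 to compound 3 (0.43 log units; beyond the scatter) and so shows that the group held here can change how fast the compound is removed. Going by these compounds alone, the earlier compounds held no pair differing in one place, which makes this the first single change at this position that can be read, and its direction is towards faster removal. Nothing in the data given explains why this change raises the number.

Going by these compounds, it remains open whether the step follows the sulfur in place of oxygen or the shorter chain, and methoxy or ethylsulfanyl on the same carbon would separate the two. An amine such as methylamino there would show whether other linking atoms move the number as well.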